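The compounds below may be only part of what the source reports. "The series", "measured", "known", "first", "only" and "open" are said of these compounds alone.

Measured so far:
compound 1, `O=[N+]([O-])c1cc(Sc2nnnn2C2CCCCC2)cc([N+](=O)[O-])c1`, with 153000 nM
compound 2, `Cc1ccc(Cn2nnc(-c3cc([N+](=O)[O-])cc([N+](=O)[O-])c3)n2)cc1`, with 200000 nM

Both compounds were tested in an ADME assay on CHO-K1 cells (Cricetulus griseus) for cytotoxicity, read by MTT assay, with a stated time of 24 h; on this read-out lower numbers stand for stronger inhibition and higher numbers for weaker inhibition. Compound 2 and compound 1 lie within the usual scatter of each other in this assay, so neither can be placed above the other; both simply show weak inhibition of the cells, with large numbers on this read-out.

Compound 3, `O=[N+]([O-])c1cc(-c2nnn(Cc3ccccc3F)n2)cc([N+](=O)[O-])c1`, is not yet measured. It differs from compound 2 in one place: 2-fluorophenyl in place of 4-methylphenyl on a saturated chain carbon bound to an aromatic nitrogen. The shared core of compound 2 and compound 3, with its two nitro groups, is untouched; only the ring hanging off the saturated chain carbon changes, one small substituent for another, with no change in donors, acceptors or charge.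

Among the measured compounds shown here, no step between two measured compounds is available to show what such a swap does in this assay. With nothing in the data pointing either way, the step from compound 2 to compound 3 is expected to stay within the scatter, a 1.1-fold lower number from compound 2 to compound 3 (0.02 log units; within the scatter). Compound 3 is therefore estimated at 190000 nM, with a range from 95000 nM to 380000 nM.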

Compound 3, half-maximal inhibitory concentration: > 200000 nM
Compound 3: no number, only a limit; the forecaster's own chance of this, stated with the estimate: 30%; middle value at least 1.0-fold (0.02 log units) away from the limit.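

In this assay, compound 3 gives > 200000 nM, which is a limit of the assay and not a number. Placing 2-fluorophenyl where 4-methylphenyl stood, on a saturated chain carbon bound to an aromatic nitrogen, gives a number no lower from compound 2 to compound 3 (the limit leaves the size open), the first direct look at a change in this position, and it shows no stronger inhibition of the cells. The size of the step cannot be read, and the reason lies in a single fact: the limit of > 200000 nM in this assay, at which 1 of the 3 values shown sits.

The compounds shown leave open whether any group on this saturated chain carbon can bring the number down in this assay, as only 4-methylphenyl and 2-fluorophenyl stand there so far, and a ring carrying an amine or a carboxylic acid would be a much larger change than the one seen here. Also open, going by these compounds, is what the two nitro groups of the shared core mean for this read-out, as both stay in place in compound 2 and compound 3, and a version of compound 3 with an amine in place of one nitro group would test that directly.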